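Amide aryl variation in a flavonol series

The source may report more compounds than this note shows. Statements on the series, on what has been measured and on what is new or still open speak of the compounds shown alone.

Three analogues sharing one core have been measured in a functional assay on A549 cells (Homo sapiens) for antiproliferative activity, read by CCK-8 assay, with a stated time of 72 h; a higher number here means a weaker inhibitor, a lower number a stronger inhibitor. Compound 1 `O=C(Nc1cccc(-c2oc3cc(-c4ccc(F)cc4)ccc3c(=O)c2O)c1)c1ccc(F)cc1F` gives 20500 nM, compound 2 `O=C(Nc1cccc(-c2oc3cc(-c4ccc(F)cc4)ccc3c(=O)c2O)c1)c1ccc(C(F)(F)F)cc1` gives 19400 nM, and compound 3 `Cc1cc(C(=O)Nc2cccc(-c3oc4cc(-c5ccc(F)cc5)ccc4c(=O)c3O)c2)ccc1F` gives 11500 nM. Compound 3 carries the lowest of the three numbers, but its separations from the others, a 1.8-fold lower number from compound 1 to compound 3 (0.25 log units; within the scatter) and a 1.7-fold lower number from compound 2 to compound 3 (0.23 log units; within the scatter), both sit within the scatter, as does a 1.1-fold lower number from compound 1 to compound 2 (0.02 log units; within the scatter). Compound 4 `Cc1cc(C)cc(C(=O)Nc2cccc(-c3oc4cc(-c5ccc(F)cc5)ccc4c(=O)c3O)c2)c1` differs from compound 3 by 3,5-dimethylphenyl in place of 4-fluoro-3-methylphenyl on a carbonyl carbon. All three measured steps bear on this change, since each swaps the aryl on the carbonyl, and none moved the number beyond the scatter. The expected step of a 1.1-fold higher number from compound 3 to compound 4 (0.05 log units; within the scatter) is therefore no change beyond the scatter. Compound 4 is estimated at 13000 nM, within a range of 5500 nM to 31000 nM.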

Compound 4, half-maximal inhibitory concentration: 3740 nM
Beside the measured number, compound 4's estimate is 3.5-fold (0.54 log units) above it; measured number outside the range, below it.
By their numbers in this assay, from the lowest: compound 4; then compounds 3, 2 and 1 (each within the scatter of the next).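

The aryl on the carbonyl, which moved nothing beyond the scatter among compound 1, compound 2 and compound 3, does matter at this position: a 3.1-fold lower number from compound 3 to compound 4 (0.49 log units; beyond the scatter), with a 5.2-fold lower number from compound 2 to compound 4 (0.71 log units; beyond the scatter) and a 5.5-fold lower number from compound 1 to compound 4 (0.74 log units; beyond the scatter). Of the four aryls, 3,5-dimethylphenyl is the only one without fluorine, and it gives the lowest number. Nothing on hand explains this step.

Going by these compounds, whether the gain follows the loss of fluorine or the placing of the two methyl groups stays open. A 3-methylphenyl, a 3,5-dichlorophenyl or a 3,5-dimethoxyphenyl on the same carbonyl would separate these readings.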